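Aryl exchange on a ring amine nitrogen: compound 3 to compound 4

The source may hold more compounds than are shown below. What is called first, only, known or untested is meant among the compounds shown, and "the series" means these compounds.

Of the compounds shown here, three sharing one core have been measured in a functional assay on CHO cells with adenosine receptor A1 (Homo sapiens) as the target, read by cAMP accumulation and immunoassay, with a stated time of 6 min, tested at 0.01 uM; on this read-out lower numbers stand for a stronger effect and higher numbers for a weaker effect at the one concentration tested. Compound 1 `Nc1scc(CN2CCN(c3ccc(Cl)c(C(F)(F)F)c3)CC2)c1C(=O)c1ccc(Cl)cc1` gives -2.5%, compound 2 `Nc1scc(CN2CCN(c3cccc4ccccc34)CC2)c1C(=O)c1ccc(Cl)cc1` gives 8.7%, and compound 3 `Nc1scc(CN2CCN(c3ccc(F)cc3F)CC2)c1C(=O)c1ccc(Cl)cc1` gives 0%. Compound 3 thus holds the second highest of the three numbers; its nearest neighbour is compound 1 and its furthest is compound 2, and both of those gaps are within the scatter. Compound 4 `Nc1scc(CN2CCN(c3cc(Cl)ccc3Cl)CC2)c1C(=O)c1ccc(Cl)cc1` has not yet been measured. It differs from compound 3 in one place: 2,5-dichlorophenyl in place of 2,4-difluorophenyl on an amine nitrogen in a ring.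

Within the data shown here, three measured steps bear on this change, each exchanging the aryl group on the same amine nitrogen in a ring. The step of a number 2.5 percentage points higher from compound 1 to compound 3 (within the scatter) and the step of a number 8.7 percentage points lower from compound 2 to compound 3 (within the scatter) both fall within the scatter, while a number 11.2 percentage points higher from compound 1 to compound 2 (beyond the scatter) is the only one that rises beyond it, and only modestly. No shift beyond the scatter is expected for compound 4 because a number 11.2 percentage points higher from compound 1 to compound 2 (beyond the scatter) was the largest aryl exchange seen and stayed modest, so the expected step is a number 2 percentage points higher from compound 3 to compound 4 (within the scatter). Compound 4 is therefore estimated at 2% in this assay, with a range from -10% to 14%.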

Compound 4, a percentage reported as activity, at one concentration (the size of the read-out at that concentration, not a potency): 13%
Compound 4: middle estimate off by 11 percentage points, on the low side; measured number inside the range.
By their numbers in this assay, from the lowest: compounds 1, 3, 2 and 4 (each within the scatter of the next, the first and the last beyond it).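

In this assay, a number 13 percentage points higher from compound 3 to compound 4 (beyond the scatter), so an exchange between two dihalophenyl groups can move the number beyond the scatter, although the groups match in heavy atoms, aromatic ring, hydrogen-bond donors and acceptors, and charge. The largest step yet seen at this amine nitrogen is a number 15.5 percentage points higher from compound 1 to compound 4 (beyond the scatter), and it is still modest, so the aryl exchanges shown stay within a narrow span at the one concentration tested. With a number 4.3 percentage points higher from compound 2 to compound 4 (within the scatter), the 2,5-dichlorophenyl and naphthalen-1-yl groups cannot be told apart here, and both stand beyond the scatter from the 4-chloro-3-(trifluoromethyl)phenyl group of compound 1, but compound 3 goes against any clean split into two sets, lying within the scatter of both compound 1 and compound 2.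

Nothing in the data at hand accounts for these steps. The exchange from compound 3 to compound 4 changes both the halogen and its placement, and the compounds shown do not separate the two, nor do they tell how a plain phenyl, a pyridyl ring or an acetyl group on this nitrogen would read.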